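Swapping the aryl substituent of a thiourea on a shared core

The compounds below may be only part of what the source reports. "The series", "measured", "known", "first", "only" and "open" are said of these compounds alone.

Compound 1 `NC(=O)c1c(NC(=O)c2ccccc2Cl)sc2c1CCNC2`, compound 2 `NC(=O)c1c(NC(=O)c2ccccc2Cl)sc2c1CCN(Cc1ccccc1Cl)C2` and compound 3 `CSc1ccccc1NC(=S)N1CCc2c(sc(NC(=O)c3ccccc3Cl)c2C(N)=O)C1` share one core and differ only at the amine nitrogen in the ring. In a functional assay on HeLa cells (Homo sapiens) for antiproliferative activity, with a stated time of 24 h (a higher number here means a weaker inhibitor, a lower number a stronger inhibitor), compound 1 gives 45000 nM, compound 2 gives 27500 nM, and compound 3 gives 43600 nM, the second highest of the three numbers and within the scatter of both others, as shown by a 1.0-fold lower number from compound 1 to compound 3 (0.01 log units; within the scatter) and a 1.6-fold higher number from compound 2 to compound 3 (0.20 log units; within the scatter). Compound 4 `COc1ccc(NC(=S)N2CCc3c(sc(NC(=O)c4ccccc4Cl)c3C(N)=O)C2)cc1` carries 4-methoxyphenyl in place of 2-(methylsulfanyl)phenyl on an amide-type nitrogen. Within the data shown here, no measured step touches that aryl group, and every step in the set, including a 1.6-fold lower number from compound 1 to compound 2 (0.21 log units; within the scatter), stays within the scatter; the step expected in this assay is therefore a 1.1-fold lower number from compound 3 to compound 4 (0.04 log units; within the scatter), nothing beyond the scatter. Compound 4 is estimated at 40000 nM, with a range of 15000 nM to 100000 nM.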

Compound 4, half-maximal inhibitory concentration: 36400 nM
Beside the measured number, compound 4's estimate is 1.1-fold (0.04 log units) above it, within the range that was stated.
By their numbers in this assay, from the lowest: compounds 2, 4, 3 and 1 (each within the scatter of the next).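

In this assay, the aryl group on the thiourea is now exchanged directly, with 4-methoxyphenyl in place of 2-(methylsulfanyl)phenyl on the amide-type nitrogen giving a 1.2-fold lower number from compound 3 to compound 4 (0.08 log units; within the scatter), so this swap stays within the scatter. Compound 4 also remains within the scatter of the two compounds without a thiourea, with a 1.3-fold higher number from compound 2 to compound 4 (0.12 log units; within the scatter) and a 1.2-fold lower number from compound 1 to compound 4 (0.09 log units; within the scatter). No outside evidence bears on this result. As far as these compounds go, whether an amine or a carboxylic acid on that aryl ring, or a longer alkyl chain in its place, would give a step beyond the scatter stays open.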